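The source may report more compounds than this note shows. Statements on the series, on what has been measured and on what is new or still open speak of the compounds shown alone.

Measured in a functional assay for inhibition, with Rattus norvegicus as the target; a lower number here means a stronger inhibitor, a higher number a weaker inhibitor:
- compound 1 `CCOC(=O)c1c(CC)c(OC)c2ccccc2c1OC(C)=O`: 3760 nM
- compound 2 `CCc1c(CC)c(OC(C)=O)c2ccccc2c1OC`: 400 nM
- compound 3 `CCc1c(CC)c(OC)c2c(OC)cccc2c1OC(C)=O`: 890 nM

Compound 2 has the lowest number of the three, at 400 nM. Compound 4 `CCCCc1cccc2c(OC)c(CC)c(CC)c(OC(C)=O)c12` differs from it by butyl in place of hydrogen on an aromatic carbon.

The nearest measured precedent is a 2.2-fold higher number from compound 2 to compound 3 (0.35 log units; beyond the scatter), which also replaces hydrogen on an aromatic carbon. The other measured change, a 9.4-fold lower number from compound 1 to compound 2 (0.97 log units; beyond the scatter), concerns a different substituent and bears on this step only as a guide to how large changes can be in this series. Among the measured compounds shown here, no measured compound carries butyl, so the range stays wide. A modest move towards a higher number is expected, with an estimated 2.0-fold higher number from compound 2 to compound 4 (0.30 log units; within the scatter).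

For compound 4 the estimate is 800 nM, with an expected range of 250 nM to 2800 nM.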

Compound 4, half-maximal inhibitory concentration: 14100 nM
The estimate for compound 4 lay 18-fold (1.25 log units) below the measured number, and the stated range ends below it.
By their numbers in this assay, from the lowest: compound 2; then compound 3; then compound 1; then compound 4.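

In this assay, butyl in place of hydrogen on an aromatic carbon gives a 35-fold higher number from compound 2 to compound 4 (1.55 log units; beyond the scatter) and leaves compound 4 with the highest number of the series. Replacing hydrogen on this ring system is therefore not always a modest change, since the methoxy replacement, at a different carbon, gives only a 2.2-fold higher number from compound 2 to compound 3 (0.35 log units; beyond the scatter) in the same assay. At this carbon, ortho to a fused ring, the hydrogen of compound 2 gives a far lower number than butyl.

Going by these compounds, whether methyl, a longer chain, an amine or a carboxylic acid at this carbon would give a number nearer that of compound 2 remains open. Nothing available bears on the reason for the large rise.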